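A few compounds are considered here, and "the series" means these few. Any claim that something is new, unique, unknown or untested is made for them only; others in the source may bear on it.

Measured so far:
compound 1, `C#CCN(C)CCCCCOc1ccc2c(c1)CCC2=O` — 31%
compound 2, `C#CCN(C)CCCCCCOc1ccc2c(c1)CCC2=O` — 4.42%
compound 3, `C#CCN(C)CCCCOc1ccc(C(C)=O)cc1OC` — 21.1%

All three numbers come from an ADME assay on BTI cells for inhibition of Amine oxidase [flavin-containing] A (Homo sapiens), read by fluorescence and Amplex Red, with a stated time of 15 min, tested at 100 uM; on this read-out higher numbers stand for more inhibition at the one concentration tested (going by the name of the read-out) and lower numbers for less inhibition. Within the core shared by compound 1 and compound 2, the change (methyl(propargyl)amino)methyl in place of methyl(propargyl)amino on a saturated chain carbon, five bonds along the chain from an oxygen on an aromatic ring gave a number 26.6 percentage points lower from compound 1 to compound 2 (beyond the scatter). Compound 3 carries a different core; how it differs from the core of compound 1 is not broken down here. Compound 3 stands nearest to compound 1 and furthest from compound 2 in this assay.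

Compound 4, `C#CCN(C)CCCCCOc1ccc(C(C)=O)cc1OC`, is not yet measured. It differs from compound 3 by (methyl(propargyl)amino)methyl in place of methyl(propargyl)amino on a saturated chain carbon, four bonds along the chain from an oxygen on an aromatic ring. This is the same kind of change as that from compound 1 to compound 2, but not the same: there the place lay five bonds along the chain from the aromatic oxygen, here four. The step is expected to be a number 9.1 percentage points lower from compound 3 to compound 4 (within the scatter), downward, resting on a number 26.6 percentage points lower from compound 1 to compound 2 (beyond the scatter) in the other core, while the different core and the shorter chain leave the size uncertain. Compound 4 is therefore estimated at 12%, between 0% and 30%.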

Compound 4, a percentage reported as inhibition, at one concentration (the size of the read-out at that concentration, not a potency): 39.5%
Compound 4: the middle estimate sits 27.5 percentage points below what was measured, and the stated range ends below it.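

In this assay the same lengthening of the chain does not carry over from one core to the other: the same change on two cores in this assay, a number 26.6 percentage points lower (beyond the scatter) from compound 1 to compound 2 and a number 18.4 percentage points higher (beyond the scatter) from compound 3 to compound 4, 45 percentage points apart, beyond the scatter of two such steps The new step, a number 18.4 percentage points higher from compound 3 to compound 4 (beyond the scatter), runs against the earlier one, so a step read on the core of compound 1 gives no guide to its direction on the core of compound 3. The two pairs differ both in core and in the place of the change, so they do not show which of these two differences sets the direction.

A shorter chain on the core of compound 1 or a 2-(methyl(propargyl)amino)ethyl chain on the core of compound 3 would bear on that question. Also open, from the compounds shown here alone, is how either core behaves with a primary amine in place of methyl(propargyl)amino.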